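A few compounds are considered here, and "the series" means these few. Any claim that something is new, unique, unknown or untested is made for them only; others in the source may bear on it.

Compound 1 `CCOC(=O)c1cnc2ccc(-c3cnc(OC)c(NS(=O)(=O)c4ccc(F)cc4F)c3)cn12`: in a functional assay on A549 cells (Homo sapiens) for antiproliferative activity, read by sulforhodamine B assay, with a stated time of 72 h (on this read-out lower numbers stand for stronger inhibition and higher numbers for weaker inhibition), compound 1 gives 300 nM.
Compound 2 `CCOC(=O)c1cnc2ccc(-c3cnc(OC)c(NS(C)(=O)=O)c3)cn12`: in this assay compound 2 gives 230 nM.

Among the measured compounds shown here, compound 2 stands beside compound 1 as the only other measured compound, and the step of a 1.3-fold lower number from compound 1 to compound 2 (0.12 log units; within the scatter) is within the scatter, so the two cannot be told apart in this assay. Compound 3 `CCOC(=O)c1cnc2ccc(-c3cnc(OC)c(NS(=O)(=O)c4ccc(F)cc4)c3)cn12` has not yet been tested. It differs from compound 2 in one place: 4-fluorophenyl in place of methyl on a sulfonyl sulfur. For the measured compounds named here, the only measured step that bears on this change is a 1.3-fold lower number from compound 1 to compound 2 (0.12 log units; within the scatter), where a fluorinated ring and a methyl on the same sulfonyl sulfur gave numbers within the scatter of each other. Since 4-fluorophenyl, like 2,4-difluorophenyl, is a fluorinated ring on that sulfur, no step beyond the scatter is expected in this assay from compound 2 to compound 3. Compound 3 is therefore expected to give about 270 nM, in a range of 130 nM to 550 nM, which means an expected step of a 1.2-fold higher number from compound 2 to compound 3 (0.07 log units; within the scatter).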

Compound 3, half-maximal inhibitory concentration: 510 nM
Compound 3: middle estimate off by 1.9-fold (0.28 log units), on the low side, within the range that was stated.
By their numbers in this assay, from the lowest: compounds 2, 1 and 3 (each within the scatter of the next, the first and the last beyond it).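

In this assay, among the compounds shown here, the change on the sulfonyl sulfur now gives a first step beyond the scatter, though a modest one: a 2.2-fold higher number from compound 2 to compound 3 (0.35 log units; beyond the scatter) shows that 4-fluorophenyl in place of methyl is not neutral at this place. Yet aromatic rings on that sulfur do not separate from methyl as a class, since compound 1, with its 2,4-difluorophenyl, stays within the scatter of compound 2, and compound 3 is the one that goes against any simple rule. Removing one fluoro gives a 1.7-fold higher number from compound 1 to compound 3 (0.23 log units; within the scatter) and so cannot be told apart from no change. Nothing measured here speaks to the reason for the step.

Still open, as far as these compounds go, is how an amine, a carboxylic acid or a longer chain such as butyl on the sulfonyl sulfur would compare with methyl.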